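The source may report more compounds than this note shows. Statements on the series, on what has been measured and on what is new or still open speak of the compounds shown alone.

Compound 1 `Clc1cccc2sc(Nc3nc4ccccc4s3)nc12` was examined in a functional assay on THP-1 cells (Homo sapiens) for cytotoxicity, read by MTT assay, with a stated time of 48 h; on this read-out higher numbers stand for weaker inhibition and lower numbers for stronger inhibition. In this assay compound 1 gives only a limit, > 50000 nM, rather than a number. That places compound 1 at the limit of > 50000 nM in this assay, at which 1 of the 2 values shown sits, so its standing can be told only as a limit. A second compound, compound 2 `CCOc1ccc2nc(Nc3nc4ccc(F)cc4s3)sc2c1`, gives 39000 nM in this assay, a number rather than a limit. For the measured compounds named here, no pair of measured compounds differing in one place is available here, so no measured step can be drawn on.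

Compound 3 `c1ccc2sc(Nc3nc4ccccc4s3)nc2c1` has not yet been measured in this assay. It differs from compound 1 in a single place: hydrogen in place of chloro on an aromatic carbon. With nothing measured on either side of such a change, the step from compound 1 to compound 3 is expected to be small, a step that the limit leaves unreadable from compound 1 to compound 3, within the scatter or still at the limit. Compound 3 is therefore expected to give about 60000 nM in this assay, with a range from 25000 nM to 150000 nM.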

Compound 3, half-maximal inhibitory concentration: 28800 nM
Compound 3: middle estimate off by 2.1-fold (0.32 log units), on the high side; the range from low to high includes it.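

With hydrogen on this aromatic carbon, the shared core yields a number rather than a limit: in this assay compound 3 gives 28800 nM as a measured value. Compound 1 gives > 50000 nM in the same assay, which is a limit and not a number. The change from chloro to hydrogen at this place therefore reads only as an at least 1.7-fold lower number from compound 1 to compound 3 (0.23 log units; that floor lies within the scatter) and shows no step beyond the scatter, while its true size stays hidden: the limit of > 50000 nM in this assay, at which 1 of the 3 values shown sits.

As far as these compounds go, how far the number for compound 1 really lies from that of compound 3 remains open. So does what a methoxy group, an amine or a carboxylic acid on this same aromatic carbon would do in this assay to the number seen with hydrogen.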